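Swapping a Branched Ether Amine for Diethylamino

The compounds below may be only part of what the source reports. "The series", "measured", "known", "first", "only" and "open" are said of these compounds alone.

Compound 1, `CCCN(CC1CC1)c1nc(C)nc2c(-c3ccc(Cl)cc3Cl)c(C)nn12`: 0.7 nM
Compound 2, `CCOCC(COCC)Nc1nc(C)nc2c(-c3ccc(Cl)cc3Cl)c(C)nn12`: 6.2 nM
Compound 3, `CCC(COC)Nc1nc(C)nc2c(-c3ccc(Cl)cc3Cl)c(C)nn12`: 1.9 nM

In an assay on isolated protein for displacement of a labelled ligand from corticotropin-releasing factor receptor 1 (Homo sapiens) (a lower number here means a stronger inhibitor, a higher number a weaker inhibitor), compound 3 stands second highest of the three numbers, with compound 1 nearest and compound 2 furthest. The two measured steps are a 2.7-fold higher number from compound 1 to compound 3 (0.43 log units; beyond the scatter) and a 3.3-fold lower number from compound 2 to compound 3 (0.51 log units; beyond the scatter). Compound 4, `CCN(CC)c1nc(C)nc2c(-c3ccc(Cl)cc3Cl)c(C)nn12`, differs from compound 3 in one place: diethylamino in place of (1-(methoxymethyl)propyl)amino on an aromatic carbon. The precedent that bears most on this is a 2.7-fold higher number from compound 1 to compound 3 (0.43 log units; beyond the scatter), which likewise exchanged an amine carrying two alkyl groups for the ether-bearing secondary amine; running that exchange the other way points to a somewhat lower number, although diethylamino is smaller than (cyclopropylmethyl)(propyl)amino. The step from compound 2 to compound 3 is only indirectly relevant. Compound 4 is therefore expected to show a 1.3-fold lower number from compound 3 to compound 4 (0.10 log units; within the scatter), estimated at 1.5 nM with a range from 0.5 nM to 5 nM.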

Compound 4, inhibition constant: 1.2 nM
The estimate for compound 4 lay 1.3-fold (0.10 log units) above the measured number; the range from low to high includes it.
By their numbers in this assay, from the lowest: compounds 1, 4 and 3 (each within the scatter of the next, the first and the last beyond it); then compound 2.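

In this assay, diethylamino in place of (1-(methoxymethyl)propyl)amino on the aromatic carbon gives a 1.6-fold lower number from compound 3 to compound 4 (0.20 log units; within the scatter) and so removes the group's hydrogen-bond donor and ether oxygen with no change beyond the scatter. Diethylamino in place of (cyclopropylmethyl)(propyl)amino gives a 1.7-fold higher number from compound 1 to compound 4 (0.23 log units; within the scatter) and is also within the scatter, so the smaller group holds up against both neighbours. No measurement shown here offers a reason for either step. Still open, going by these compounds, is how a ring amine such as morpholine or pyrrolidine would fare at this carbon. A simple sec-butylamino group would test the amine hydrogen apart from the ether oxygen.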